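Replacing the thiocarbamate of compound 3 with a pyrimidine amide

A few compounds are considered here, and "the series" means these few. Any claim that something is new, unique, unknown or untested is made for them only; others in the source may bear on it.

In a functional assay on isolated protein for inhibition of Glucose-dependent insulinotropic receptor (Rattus norvegicus), read by HTRF and cAMP accumulation (on this read-out higher numbers stand for an effect only at larger amounts of compound and lower numbers for an effect already at smaller amounts), compound 3 `Cc1nc(S(C)(=O)=O)ccc1Oc1ncnc(OC2CCN(C(=S)OC3(C)CC3)CC2)c1F` gives 48.8 nM, the lowest of the three numbers: compound 1 `Cc1nc(S(C)(=O)=O)ccc1Oc1ncnc(OC2CCN(C(=O)OC(C)(C)C#N)CC2)c1F` gives 1320 nM and compound 2 `CCC1(OC(=O)N2CCC(Oc3ncnc(Oc4ccc(S(C)(=O)=O)nc4C)c3F)CC2)CC1` gives 333 nM. Both steps towards compound 3 are large or modest, a 27-fold lower number from compound 1 to compound 3 (1.43 log units; beyond the scatter) and a 6.8-fold lower number from compound 2 to compound 3 (0.83 log units; beyond the scatter), and the step of a 4.0-fold lower number from compound 1 to compound 2 (0.60 log units; beyond the scatter) shows that the group on the ring nitrogen matters. Compound 4 `CCc1cnc(C(=O)N2CCC(Oc3ncnc(Oc4ccc(S(C)(=O)=O)nc4C)c3F)CC2)nc1` carries a group of 10 heavy atoms (7 carbon, 2 nitrogen, 1 oxygen; one six-membered aromatic ring with 2 hetero atoms) in place of a group of 7 heavy atoms (5 carbon, 1 oxygen, 1 sulfur; one three-membered non-aromatic ring of carbon only), on an amine nitrogen in a ring. Among the measured compounds shown here, no measured step brings an aromatic ring onto that nitrogen, so the direction rests only on compound 3 holding the best value so far, 48.8 nM, which leaves more room to climb than to fall. The expected step is a 4.1-fold higher number from compound 3 to compound 4 (0.61 log units; beyond the scatter), a modest rise. For compound 4 the estimate is 200 nM, expected between 50 nM and 800 nM.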

Compound 4, half-maximal effective concentration: 40.8 nM
Compound 4: the middle estimate sits 4.9-fold (0.69 log units) above what was measured; measured number below the stated range.
By their numbers in this assay, from the lowest: compounds 4 and 3 (each within the scatter of the next); then compound 2; then compound 1.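

With a 1.2-fold lower number from compound 3 to compound 4 (0.08 log units; within the scatter) in this assay, the 5-ethylpyrimidin-2-yl amide on the amine nitrogen in a ring matches the thiocarbamate, so this position accepts an aromatic ring with 2 hetero atoms and does not depend on the sulfur. On the carbonyl carbon, the same group improves on both carbamates, with an 8.2-fold lower number from compound 2 to compound 4 (0.91 log units; beyond the scatter) and a 32-fold lower number from compound 1 to compound 4 (1.51 log units; beyond the scatter). No measurement offered here accounts for these steps. From the compounds shown here alone, it remains open what a longer chain or an amine in place of the ethyl would do, and whether a plain phenyl ring could replace the pyrimidine.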